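The compounds below may be only part of what the source reports. "The series", "measured", "known", "first", "only" and "open" are said of these compounds alone.

Measured so far:
compound 1 `O=C(NCCCCN1CCN(c2ccc(Cl)cc2)CC1)c1ccc(-c2ccsc2)cc1`: 0.837 h
compound 2 `O=C(NCCCCN1CCN(c2ccc(O)cc2)CC1)c1ccc(-c2ccsc2)cc1`: 0.19 h

In an ADME assay on microsomes from liver (Rattus norvegicus) for metabolic stability, read by LC-MS, using NADPH (a higher number here means that the compound lasts longer, a lower number that the compound disappears faster), compound 2 gives 0.19 h, the lower of the two numbers, while compound 1 gives 0.837 h. Compound 3 `O=C(NCCCCN1CCN(c2ccc(C(F)(F)F)cc2)CC1)c1ccc(-c2ccsc2)cc1` differs from compound 2 by trifluoromethyl in place of hydroxy on an aromatic carbon. Within the data shown here, no measured step involves a trifluoromethyl group, so the only step that bears on this one is a 4.4-fold lower number from compound 1 to compound 2 (0.64 log units; beyond the scatter). Undoing the hydroxy, this time in favour of a group with no hydrogen-bond donor, is expected to give a step of roughly a 4.7-fold higher number from compound 2 to compound 3 (0.68 log units; beyond the scatter) in this assay. Compound 3 is therefore estimated at 0.9 h, with a range of 0.3 h to 2.5 h.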

Compound 3, half-life: > 1 h
Compound 3: only a limit was reported; the forecaster's own chance of this, stated with the estimate: 5%; at least 1.1-fold (0.04 log units) between middle value and limit.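

In this assay compound 3 gives > 1 h, which is a limit and not a number: the limit of > 1 h in this assay, at which 1 of the 3 values shown sits. A second group in place of hydroxy on this aromatic carbon now also gives a longer half-life, with trifluoromethyl producing an at least 5.2-fold higher number from compound 2 to compound 3 (0.72 log units; beyond the scatter). Against chloro, the same position gives an at least 1.1-fold higher number from compound 1 to compound 3 (0.07 log units; that floor lies within the scatter), so no order between these two groups can be drawn. Still open, going by these compounds, is how far the half-life of compound 3 extends. Also open, on these data alone, is whether methoxy, an amine or a carboxylic acid here would track hydroxy or chloro.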